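Ester chain length and cytotoxicity read-out in the series

A few compounds are considered here, and "the series" means these few. Any claim that something is new, unique, unknown or untested is made for them only; others in the source may bear on it.

Measured compounds:
compound 1 `CCCCCCCCOC(=O)CCC(=O)N1CCN(CCCOc2cc3c(Nc4ccc(F)c(Cl)c4)ncnc3cc2OC)CC1` gives 21.7% in a functional assay on A549 cells (Homo sapiens) for cytotoxicity, read by MTT assay, with a stated time of 24 h, tested at 80 uM; on this read-out lower numbers stand for a stronger effect and higher numbers for a weaker effect at the one concentration tested
compound 2 `CCCCCCCCCCCCOC(=O)CCC(=O)N1CCN(CCCOc2cc3c(Nc4ccc(F)c(Cl)c4)ncnc3cc2OC)CC1` gives 2.3% in this assay
compound 3 `CCCCCCCCCCCCCCCOC(=O)CCC(=O)N1CCN(CCCOc2cc3c(Nc4ccc(F)c(Cl)c4)ncnc3cc2OC)CC1` gives 81.1% in this assay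

Compound 3 carries the highest number of the three, that is the weakest effect seen so far; its nearest neighbour is compound 1 and its furthest is compound 2, both beyond the scatter. Compound 4 `CCCCCCCCCCCCCCCCCCCCOC(=O)CCC(=O)N1CCN(CCCOc2cc3c(Nc4ccc(F)c(Cl)c4)ncnc3cc2OC)CC1` differs from compound 3 by pentyl in place of hydrogen on a saturated chain carbon, ten or more bonds along the chain from an oxygen next to a carbonyl group, so it continues the lengthening of the ester chain.

Going by the values given here, two measured steps bear on this change: a number 78.8 percentage points higher from compound 2 to compound 3 (beyond the scatter), which is the same kind of extension at the same place, and a number 59.4 percentage points higher from compound 1 to compound 3 (beyond the scatter). Both were large rises in the read-out. Among the compounds with values here, the one step running the other way, a number 19.4 percentage points lower from compound 1 to compound 2 (beyond the scatter), sits earlier in the chain and is modest. Within the data shown here, only three points are available and the course from compound 1 through compound 2 to compound 3 is not monotonic, so no rule beyond these compounds is claimed.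

The expectation for compound 4 is a further rise from compound 3, or at least no fall, as a number 6.9 percentage points higher from compound 3 to compound 4 (within the scatter). Compound 4 is estimated at 88%, in the range 60% to 100% in this assay.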

Compound 4, a percentage reported as activity, at one concentration (the size of the read-out at that concentration, not a potency): 85.2%
Compound 4: middle estimate off by 2.8 percentage points, on the high side, and the stated range covers the measured number.
By their numbers in this assay, from the lowest: compound 2; then compound 1; then compounds 3 and 4 (each within the scatter of the next).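

In this assay, going by these compounds alone, the pentyl extension on a saturated chain carbon gives a number 4.1 percentage points higher from compound 3 to compound 4 (within the scatter); this is the first extension that leaves two compounds indistinguishable, whereas each earlier one moved the read-out beyond the scatter. Against the shorter chains the separation remains large, at a number 82.9 percentage points higher from compound 2 to compound 4 (beyond the scatter) and a number 63.5 percentage points higher from compound 1 to compound 4 (beyond the scatter), so compound 3 and compound 4 sit together apart from compound 1 and compound 2, and compound 2 remains the compound with the strongest effect at the one concentration tested. The four compounds therefore suggest a sharp turn after compound 2 followed by a flat stretch, though compound 1 goes against any steady trend with chain length, and no supporting data are available to account for either feature.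

The compounds shown leave open where the turn lies among chains of a length between those of compound 2 and compound 3, and whether a longer chain than that of compound 4 stays level with it. They also leave open whether an amine or a carboxylic acid at the far end of the chain would alter the read-out at this place.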